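The compounds below may be only part of what the source reports. "The series", "measured", "known", "first", "only" and "open" are said of these compounds alone.

Compound 1, `CO[C@@H]1C/C=C(\C)C(=O)N(C)[C@@H](C(C)C)C(=O)N[C@H](Cc2ccccc2)C(=O)N[C@@H](C(C)C)C(=O)O[C@H](c2ccccc2)[C@H](C)/C=C/C=C/1C`, is one of two macrocycles whose antiproliferative activity was examined in a functional assay on A549 cells (Homo sapiens) for antiproliferative activity, read by MTT assay, with a stated time of 72 h; a higher number here means a weaker inhibitor, a lower number a stronger inhibitor. In this assay compound 1 gives > 100 nM, which is a limit of the assay and not a number. Compound 2, `CO[C@@H]1C/C=C(\C)C(=O)N(C)[C@@H](C(C)C)C(=O)N[C@H](Cc2ccccc2)C(=O)N[C@@H](C(C)C)C(=O)O[C@H](c2ccccc2)C/C=C/C=C/1C`, carries hydrogen in place of methyl on a saturated ring carbon. In this assay compound 2 gives > 100 nM, again a limit. The step that the two limits leave unreadable from compound 1 to compound 2 cannot be read, since (the limit of > 100 nM in this assay, at which 2 of the 2 values shown sit). Compound 3, `COc1cc(C[C@H]2NC(=O)[C@H](C(C)C)N(C)C(=O)/C(C)=C/C[C@@H](OC)/C(C)=C/C=C/[C@@H](C)[C@@H](c3ccccc3)OC(=O)[C@H](C(C)C)NC2=O)ccc1O`, differs from compound 1 by 4-hydroxy-3-methoxyphenyl in place of phenyl on a saturated chain carbon bound to a saturated ring carbon. Within the data shown here, no measured step bears on this change, and both values shown are limits, so the direction and size of the step are open. Compound 3 is expected to sit near the same limit, with the step that the limit leaves unreadable from compound 1 to compound 3 expected to be no larger than scatter. The estimate for compound 3 in this assay is 200 nM, with a range from 50 nM to 2000 nM.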

Compound 3, half-maximal inhibitory concentration: 20.2 nM
Estimate against measurement, compound 3: 9.9-fold (1.00 log units) above, outside the stated range (below it).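

In this assay, the change to 4-hydroxy-3-methoxyphenyl on a saturated chain carbon bound to a saturated ring carbon gives an at least 4.9-fold lower number from compound 1 to compound 3 (0.69 log units; beyond the scatter), so this position carries a readable change beyond the scatter. Compound 3 is the only compound shown with a number and not a limit. The step between the earlier pair, compound 1 and compound 2, still cannot be read: the limit of > 100 nM in this assay, at which 2 of the 3 values shown sit.

The compounds shown leave open whether 4-hydroxyphenyl or 3-methoxyphenyl alone would give the same step, and whether an amine such as 4-aminophenyl would do so. They also leave open whether the methyl on the saturated ring carbon matters once 4-hydroxy-3-methoxyphenyl is in place.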